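Fluoro in Place of Methyl: Compound 3 to Compound 4

The source may hold more compounds than are shown below. What is called first, only, known or untested is meant among the compounds shown, and "the series" means these compounds.

Three compounds have been measured in an assay on isolated protein for inhibition of Dihydrofolate reductase (Homo sapiens), read by spectrophotometry; a higher number here means a weaker inhibitor, a lower number a stronger inhibitor:

compound 1, `CN(Cc1nc2cc(C(F)(F)F)ccc2nc1-c1ccccc1)c1ccc(Cl)cc1`, 5000 nM
compound 2, `CN(Cc1nc2cc(C(F)(F)F)ccc2nc1-c1ccccc1)c1ccc(F)cc1`, 5000 nM
compound 3, `CCN(Cc1nc2cc(C(F)(F)F)ccc2nc1-c1ccccc1)c1ccc(C)cc1`, 4000 nM

All three numbers sit in one narrow band. The step of no change at the digits printed from compound 1 to compound 2 (within the scatter) shows that swapping chloro for fluoro left the number where it was, and the steps of a 1.3-fold lower number from compound 1 to compound 3 (0.10 log units; within the scatter) and a 1.3-fold lower number from compound 2 to compound 3 (0.10 log units; within the scatter) are likewise within the scatter, so compound 3 cannot be set apart from the other two on these numbers.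

Compound 4, `CCN(Cc1nc2cc(C(F)(F)F)ccc2nc1-c1ccccc1)c1ccc(F)cc1`, is the next structure. It differs from compound 3 by fluoro in place of methyl on an aromatic carbon. For the measured compounds named here, no measured step isolates this exact swap: the step of a 1.3-fold lower number from compound 2 to compound 3 (0.10 log units; within the scatter) contains it, but bundled with an ethyl for methyl exchange on the nitrogen, and that bundle produced no shift beyond the scatter. Compound 4 and compound 2 share the fluoro and differ only by that ethyl, and the value of compound 2 is 5000 nM. Every change recorded so far in this assay has been flat, so the expected step of a 1.3-fold higher number from compound 3 to compound 4 (0.10 log units; within the scatter) is also flat, within the scatter. Compound 4 is therefore estimated at 5000 nM in this assay, with a range from 2500 nM to 10000 nM.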

Compound 4, inhibition constant: 3000 nM
The estimate for compound 4 lay 1.7-fold (0.22 log units) above the measured number; the measured number falls inside the stated range.
By their numbers in this assay, from the lowest: compounds 4, 3, 1 and 2 (each within the scatter of the next).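

In this assay the exchange of fluoro for methyl, on an aromatic carbon para to a large group, now stands alone with the ethyl on the nitrogen held fixed, and the record gives a 1.3-fold lower number from compound 3 to compound 4 (0.12 log units; within the scatter) as its size, so these two groups cannot be told apart at this position. For the compounds shown here, the nitrogen substituent can now also be read apart from the ring substituent: with the 4-fluorophenyl held fixed, ethyl and methyl on the nitrogen give a 1.7-fold lower number from compound 2 to compound 4 (0.22 log units; within the scatter) as their step, and even the exchange that alters both places at once, recorded as a 1.7-fold lower number from compound 1 to compound 4 (0.22 log units; within the scatter) here, does not leave the band formed by the earlier compounds. No measurement at hand bears on why these numbers lie so close together.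

As far as these compounds go, whether a carboxylic acid or an amine at this ring position, or a chain longer than ethyl on the nitrogen, would move the number beyond the scatter remains open. So does the part played by the trifluoromethyl and the phenyl group on the shared core, which are the same in all four compounds.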